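Switching the sulfonyl substituent in a K562 cell series

The source may report more compounds than this note shows. Statements on the series, on what has been measured and on what is new or still open speak of the compounds shown alone.

Compound 3 `Cn1c(=O)c(S(=O)(=O)Cc2ccc(F)cc2F)cc2cnc(Nc3ccc4[nH]ccc4c3)nc21` gives 1000 nM in a functional assay on K562 cells (Homo sapiens) for inhibition, read by trypan blue exclusion, with a stated time of 72 h (a higher number here means a weaker inhibitor, a lower number a stronger inhibitor), which is the second highest of the three numbers. Compound 2 `Cn1c(=O)c(S(=O)(=O)c2ccc(F)cc2)cc2cnc(Nc3cccc4[nH]ccc34)nc21` gives 750 nM and compound 1 `Cn1c(=O)c(S(=O)(=O)c2ccc(F)cc2F)cc2cnc(Nc3cccc4[nH]ccc34)nc21` gives 1500 nM, and compound 3 lies within the scatter of both. Compound 4 `Cn1c(=O)c(S(=O)(=O)c2ccc([N+](=O)[O-])cc2F)cc2cnc(Nc3ccc4[nH]ccc4c3)nc21` carries 2-fluoro-4-nitrophenyl in place of 2,4-difluorobenzyl on a sulfonyl sulfur. For the measured compounds named here, only one measured step touches this part of the molecule: a 2.0-fold lower number from compound 1 to compound 2 (0.30 log units; within the scatter). Going by the values given here, that step concerns a fluoro alone, whereas the change to compound 4 exchanges the whole group; no measured pair shows a nitro or a phenyl directly on the sulfonyl sulfur. With so little to lean on, a step of no change at the digits printed from compound 3 to compound 4 (within the scatter) is expected, nothing beyond the scatter. Compound 4 is therefore estimated at 1000 nM, within 350 nM to 3000 nM.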

Compound 4, half-maximal inhibitory concentration: 200 nM
The estimate for compound 4 lay 5.0-fold (0.70 log units) above the measured number; measured number outside the range, below it.
By their numbers in this assay, from the lowest: compound 4; then compounds 2, 3 and 1 (each within the scatter of the next).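

In this assay, for the compounds shown here, 2-fluoro-4-nitrophenyl in place of 2,4-difluorobenzyl on a sulfonyl sulfur gives a 5.0-fold lower number from compound 3 to compound 4 (0.70 log units; beyond the scatter), the only step touching this part of the molecule that lies beyond the scatter. The earlier step concerned a fluoro alone, whereas this one shows that exchanging the whole group can move the number. Nothing given here accounts for the step.

The compounds shown do not separate the move from benzyl to phenyl from the arrival of the nitro. They also leave open whether an amine or a nitrile in place of that nitro would give a similar number.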